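The source may report more compounds than this note shows. Statements on the series, on what has been measured and on what is new or still open speak of the compounds shown alone.

Of the compounds shown here, three built on one shared core have been measured in an ADME assay on the whole organism (plasma) for pharmacokinetics, with Rattus norvegicus as the target, with a stated time of 6 h, at a dose of 10 mg/kg by the oral route; on this read-out higher numbers stand for higher exposure at the dose given and lower numbers for lower exposure. Compound 1 `Cc1nc(NCC2CC2)nc(N[C@@H]2C[C@H](CO)[C@@H](O)[C@H]2O)c1-c1nc2ccccc2s1` gives 1410 ng.h/mL, the lowest of the three numbers, though its nearest neighbour is compound 3 and its furthest is compound 2, and both gaps lie within the scatter. Compound 2 `COCCNc1nc(C)c(-c2nc3ccccc3s2)c(N[C@@H]2C[C@H](CO)[C@@H](O)[C@H]2O)n1` gives 2630 ng.h/mL, and compound 3 `Cc1nc(NCCC(F)(F)F)nc(N[C@@H]2C[C@H](CO)[C@@H](O)[C@H]2O)c1-c1nc2ccccc2s1` gives 2560 ng.h/mL. The step of a 1.9-fold higher number from compound 1 to compound 2 (0.27 log units; within the scatter) and the step of a 1.8-fold higher number from compound 1 to compound 3 (0.26 log units; within the scatter) each replaced the cyclopropyl on the saturated chain carbon bound to a nitrogen on an aromatic ring, and neither moved the number beyond the scatter; the step of a 1.0-fold lower number from compound 2 to compound 3 (0.01 log units; within the scatter) likewise stays within it. Compound 4 `Cc1nc(NCc2nccs2)nc(N[C@@H]2C[C@H](CO)[C@@H](O)[C@H]2O)c1-c1nc2ccccc2s1` is the unmeasured compound, and it differs from compound 1 by 1,3-thiazol-2-yl in place of cyclopropyl on a saturated chain carbon bound to a nitrogen on an aromatic ring. This is a third variation at the same place, and the two measured variations there bear on it directly, both being small. Within the data shown here, no measured compound carries an aromatic group at that place, so nothing shows whether this change behaves differently. On that basis compound 4 is expected to come out close to compound 1, with a step of a 1.0-fold lower number from compound 1 to compound 4 (0.00 log units; within the scatter) that is not expected to exceed the scatter. The estimate for compound 4 is 1400 ng.h/mL, with a range from 500 ng.h/mL to 4000 ng.h/mL.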

Compound 4, area under the concentration-time curve: 242 ng.h/mL
Beside the measured number, compound 4's estimate is 5.8-fold (0.76 log units) above it, and the stated range ends above it.
By their numbers in this assay, from the lowest: compound 4; then compounds 1, 3 and 2 (each within the scatter of the next).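

In this assay, among these compounds, this position turns out not to be indifferent to the group it carries: with 1,3-thiazol-2-yl in place of cyclopropyl on a saturated chain carbon bound to a nitrogen on an aromatic ring, the result is a 5.8-fold lower number from compound 1 to compound 4 (0.77 log units; beyond the scatter) and so the first step here beyond the scatter. The comparisons with the other two groups show the same separation, with 1,3-thiazol-2-yl in place of 2,2,2-trifluoroethyl giving an 11-fold lower number from compound 3 to compound 4 (1.02 log units; beyond the scatter) and in place of methoxymethyl giving an 11-fold lower number from compound 2 to compound 4 (1.04 log units; beyond the scatter) as well, so compound 4, the only one of the four with an aromatic ring at this place, stands apart from compounds 1, 2 and 3, which lie within the scatter of one another. Nothing available bears on why the number falls with this change.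

The compounds shown leave open whether this fall belongs to aromatic rings at this place in general or to 1,3-thiazol-2-yl alone, a question that a phenyl ring on the same saturated chain carbon would help to settle. They also leave open how an amine or a longer chain would behave there.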